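The source may hold more compounds than are shown below. What is called first, only, known or untested is meant among the compounds shown, and "the series" means these compounds.

In an assay on isolated protein for inhibition of kallikrein-7 (Mus musculus), read by fluorescence, with stated times of 10 min and 30 min (on this read-out lower numbers stand for stronger inhibition and higher numbers for weaker inhibition), the two measured compounds stand as follows.

Compound 1 `CC1=NC(c2cn(S(=O)(=O)c3ccc(Cl)cc3)c3ccc(C)cc23)CN1`: > 100000 nM, which is a limit of the assay and not a number.
Compound 2 `CC1=NC(c2cn(S(=O)(=O)c3ccccc3C)c3ccc(C)cc23)CN1`: 1300 nM.

Compound 2 therefore holds the only number shown in this assay. The other value sits at the limit of > 100000 nM in this assay, at which 1 of the 2 values shown sits, and belongs to compound 1.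

Compound 3 `CC1=NC(c2cn(S(=O)(=O)c3c(Cl)cccc3Cl)c3ccc(C)cc23)CN1` differs from compound 2 by 2,6-dichlorophenyl in place of 2-methylphenyl on a sulfonyl sulfur. Going by the values given here, only one measured step bears on this position, the change of the aryl ring on the sulfonyl sulfur that gave an at least 76-fold lower number from compound 1 to compound 2 (1.88 log units; beyond the scatter). Among the compounds with values here, that step shows that the ring on the sulfonyl sulfur can move the read-out strongly, but no measured pair sets 2-methylphenyl directly against 2,6-dichlorophenyl, so the direction for compound 3 rests on that single large step alone. With both rings substituted rather than carrying 4-chlorophenyl, a step within the scatter or a modest lowering is expected, and the estimate is a 1.6-fold lower number from compound 2 to compound 3 (0.21 log units; within the scatter). Compound 3 is accordingly expected to give about 800 nM in this assay, with a range from 200 nM to 4000 nM.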

Compound 3, half-maximal inhibitory concentration: 10000 nM
The estimate for compound 3 lay 13-fold (1.10 log units) below the measured number, and the stated range ends below it.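

In this assay, the result shows that substituted rings on the sulfonyl sulfur are not interchangeable: the change to 2,6-dichlorophenyl gives a 7.7-fold higher number from compound 2 to compound 3 (0.89 log units; beyond the scatter). It also gives an at least 10-fold lower number from compound 1 to compound 3 (1.00 log units; beyond the scatter), so the read-out at this position has an intermediate level, and of the three rings shown, 2-methylphenyl gives the lowest number, with 2,6-dichlorophenyl next and 4-chlorophenyl last. The size of this second step remains open-ended, as compound 1 gives > 100000 nM, which is a limit of the assay and not a number: the limit of > 100000 nM in this assay, at which 1 of the 3 values shown sits.

The compounds shown leave open whether the higher number of compound 3 follows from the two chlorine atoms together or from the loss of the methyl group, since plain phenyl, 2-chlorophenyl and 2,6-dimethylphenyl do not appear among them. They also leave open how this read-out would respond to a carboxylic acid, an amine or a longer chain on the ring, or whether the order of these three rings would hold with any other change to the shared core.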